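Swapping the phenyl substituent on a shared core

This account rests on a few compounds, and the source may have more. Where it says the series, first, only, none or still open, it means among the compounds named here.

Compound 3 `Cc1ccccc1-c1nc2c(NC3CCCC3)ncnc2n1C` carries a 2-methylphenyl group on its core. In a functional assay on CHO cells for antagonist activity at adenosine receptor A2b (Homo sapiens), read by 33P incorporation, with a stated time of 20 min (on this read-out lower numbers stand for stronger inhibition and higher numbers for weaker inhibition), compound 3 gives only a limit of the assay, > 30000 nM. Its two measured relatives tell the same story. Compound 1 `Cn1c(-c2ccc(C(=O)O)cc2)nc2c(NC3CCCC3)ncnc21` carries a carboxy group on the phenyl ring, and in this assay compound 1 reaches only the limit > 30000 nM. Compound 2 `COc1ccc(-c2nc3c(NC4CCCC4)ncnc3n2C)cc1` bears a methoxy group instead, and in this assay compound 2 likewise stops at the limit > 30000 nM. The step that the two limits leave unreadable from compound 1 to compound 2 and the step that the two limits leave unreadable from compound 2 to compound 3 cannot be read because of the limit of > 30000 nM in this assay, at which 3 of the 3 values shown sit, so no direction of change can be drawn from these three compounds.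

Compound 4 `Cn1c(-c2ccc(Cl)cc2)nc2c(NC3CCCC3)ncnc21` has not yet been measured. It differs from compound 3 in one place: 4-chlorophenyl in place of 2-methylphenyl on an aromatic carbon. Among the compounds with values here, nothing among the measured compounds shows that changing the substituent on this phenyl ring moves the read-out away from the limit, so compound 4 is expected to stay at the weak end as well. The expected step that the limit leaves unreadable from compound 3 to compound 4 is therefore none beyond the scatter. Compound 4 is estimated at 40000 nM, within a range from 15000 nM to 150000 nM.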

Compound 4, inhibition constant: > 30000 nM
Compound 4 gave a limit, no number (the forecaster's own chance of this, stated with the estimate: 85%); the middle value lies beyond the limit too.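

In this assay compound 4 gives > 30000 nM as a limit and not a number. The steps from compound 1, compound 2 and compound 3 to compound 4 therefore cannot be read, because all four compounds stop at the same point: the limit of > 30000 nM in this assay, at which 4 of the 4 values shown sit.

The compounds shown leave open whether any substituent on this phenyl ring can bring the shared core to a measurable value.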